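The source may hold more compounds than are shown below. What is called first, only, known or untested is meant among the compounds shown, and "the series" means these compounds.

Measured so far:
compound 1, `Fc1ccc(-c2ccc(-c3ccc(-c4nc5ccccc5[nH]4)cc3)cc2)cc1`: 100000 nM
compound 2, `Oc1ccc(-c2ccc(-c3ccc(-c4nc5ccccc5[nH]4)cc3)cc2)cc1`: 100000 nM
compound 3, `COc1ccc(-c2ccc(-c3ccc(-c4nc5ccccc5[nH]4)cc3)cc2)cc1OC`: 39700 nM

In a functional assay on ZR-75-1 cells (Homo sapiens) for inhibition, read by sulforhodamine B assay (a lower number here means a stronger inhibitor of growth, a higher number a weaker inhibitor of growth), compound 2 gives the same reading as compound 1, as no change at the digits printed from compound 1 to compound 2 (within the scatter) shows, while the step of a 2.5-fold lower number from compound 2 to compound 3 (0.40 log units; beyond the scatter) is the only move beyond the scatter among these three. Compound 4, `Cc1ccc2[nH]c(-c3ccc(-c4ccc(-c5ccc(O)cc5)cc4)cc3)nc2c1`, differs from compound 2 by methyl in place of hydrogen on an aromatic carbon. Both measured steps, no change at the digits printed from compound 1 to compound 2 (within the scatter) and a 2.5-fold lower number from compound 1 to compound 3 (0.40 log units; beyond the scatter), alter the outermost ring; none touches the fused two-ring system where the methyl enters, so no direct guide exists. Absent such a guide, compound 4 is expected to stay close to compound 2, with a step of a 1.3-fold lower number from compound 2 to compound 4 (0.10 log units; within the scatter). The estimate for compound 4 is therefore 80000 nM, expected to lie between 25000 nM and 100000 nM.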

Compound 4, concentration for 50% growth inhibition: 18200 nM
Compound 4: the middle estimate sits 4.4-fold (0.64 log units) above what was measured, outside the stated range (below it).
By their numbers in this assay, from the lowest: compound 4; then compound 3; then compounds 1 and 2 (each within the scatter of the next).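

In this assay, methyl in place of hydrogen on an aromatic carbon gives a 5.5-fold lower number from compound 2 to compound 4 (0.74 log units; beyond the scatter) and so moves the reading beyond the scatter. For the compounds shown here, all the earlier steps altered the outermost ring, so this is the first sign that the fused two-ring system also affects growth inhibition, even with a change of one heavy atom. Nothing available explains this effect. As far as these compounds go, it remains open whether ethyl, methoxy or an amine at this place would act like methyl. Also open, from the compounds shown here alone, is whether methyl would give a similar step when combined with the 3,4-dimethoxyphenyl of compound 3.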